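The compounds below may be only part of what the source reports. "The series", "measured", "known", "first", "only" and "open" are said of these compounds alone.

In a functional assay on RPMI-8226 cells (Homo sapiens) for inhibition, read by sulforhodamine B assay, with a stated time of 48 h (a lower number here means a stronger inhibitor of growth, a higher number a weaker inhibitor of growth), the measured compounds stand as follows: compound 1 `CC(=O)/C(=C\c1c(-c2ccccc2)[nH]c2ccccc12)S(=O)(=O)c1ccccc1` gives 2200 nM; compound 2 `COc1ccc2[nH]c(-c3ccccc3)c(/C=C(\C#N)S(=O)(=O)c3ccccc3)c2c1` gives "not determined" (no result reported); compound 3 `N#C/C(=C\c1c(-c2ccccc2)[nH]c2ccccc12)S(=O)(=O)c1ccccc1` gives 714 nM.

Compound 3 has the lowest number of the two that were obtained; its nearest neighbour is compound 1, and the step of a 3.1-fold lower number from compound 1 to compound 3 (0.49 log units; beyond the scatter) separates them. Compound 4 `N#C/C(=C\c1c(-c2ccccc2)[nH]c2ccccc12)C(=O)c1ccccc1` differs from compound 3 by benzoyl in place of phenylsulfonyl on a double-bonded chain carbon bound to a double-bonded chain carbon and a triple-bonded carbon. Within the data shown here, no measured step bears on this change: the only step in hand, a 3.1-fold lower number from compound 1 to compound 3 (0.49 log units; beyond the scatter), concerns the other substituent on the chain, and compound 2 returned no number. The size of the step into compound 4 therefore cannot be read from the data, and the expectation is for no shift beyond the scatter, with wide uncertainty. Compound 4 is estimated at 1000 nM, within 250 nM to 4000 nM, an expected step of a 1.4-fold higher number from compound 3 to compound 4 (0.15 log units; within the scatter).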

Compound 4, concentration for 50% growth inhibition: 2400 nM
Compound 4: middle estimate off by 2.4-fold (0.38 log units), on the low side; low and high end bracket the measured number.
By their numbers in this assay, from the lowest: compound 3; then compounds 1 and 4 (each within the scatter of the next).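

With the nitrile held fixed, the phenylsulfonyl group proves not to be interchangeable with benzoyl at this place: the change gives a 3.4-fold higher number from compound 3 to compound 4 (0.53 log units; beyond the scatter) and is the first step shown for this substituent. Compound 3 now stands as the lower number in both single-change steps that reach it, from the acetyl side and from the benzoyl side. Nothing measured here accounts for this step. On these data alone, it remains open whether the phenyl ring or the sulfonyl is what counts, and whether a methylsulfonyl group or a carboxamide at this place would match compound 3.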